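Sec-butyl for allyl on the amide nitrogen

A few compounds are considered here, and "the series" means these few. Any claim that something is new, unique, unknown or untested is made for them only; others in the source may bear on it.

Three compounds have so far been measured in a functional assay on CHO cells for positive allosteric modulation of muscarinic acetylcholine receptor M5 (Homo sapiens), read by calcium flux; on this read-out lower numbers stand for smaller maximal responses and higher numbers for larger maximal responses:
Compound 1 `CCN(C(=O)C1CCN(S(=O)(=O)c2ccc3c(c2)CCC3)CC1)[C@H](C)c1ccccc1` gives 97%.
Compound 2 `CCN(C(=O)C1CCN(S(=O)(=O)c2ccc3cn[nH]c3c2)CC1)[C@H](C)c1ccccc1` gives 87%.
Compound 3 `C=CCN(Cc1ccccc1C(F)(F)F)C(=O)C1CCN(S(=O)(=O)c2ccc3[nH]ncc3c2)CC1` gives 79%.

Compound 3 stands lowest of the three numbers. Its nearest neighbour is compound 2, whose value lies within the scatter of compound 3, so no order between them can be read; compound 1 stands furthest, and that gap lies beyond the scatter. For the measured compounds named here, the only measured step, a number 10 percentage points lower from compound 1 to compound 2 (within the scatter), concerns an exchange on the sulfonyl sulfur and tells nothing about the amide nitrogen.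

Compound 4 `CCC(C)N(Cc1ccccc1C(F)(F)F)C(=O)C1CCN(S(=O)(=O)c2ccc3[nH]ncc3c2)CC1` differs from compound 3 by sec-butyl in place of allyl on an amide-type nitrogen. Going by the values given here, none of the measured steps bears on this change; both measured neighbours of compound 3 keep the allyl or ethyl group on that nitrogen untouched. Among the compounds with values here, with no step to rest on, compound 4 is expected to move no further than the scatter, that is a number 1 percentage points higher from compound 3 to compound 4 (within the scatter). Compound 4 is therefore estimated at 80%, with a range from 65% to 95%.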

Compound 4, largest response reached (reported as percent of maximum), in percent of the reference or control that the assay uses: 100%
For compound 4 the middle estimate is 20 percentage points below the measured one; the whole stated range lies below it.
By their numbers in this assay, from the lowest: compounds 3, 2, 1 and 4 (each within the scatter of the next, the first and the last beyond it).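

In this assay, sec-butyl in place of allyl on the amide-type nitrogen gives a number 21 percentage points higher from compound 3 to compound 4 (beyond the scatter). For the compounds shown here, this is the first measured step at that nitrogen, and it shows that a change there can move the maximal response beyond the scatter, whereas the only earlier step, on the sulfonyl sulfur, stayed within it. Nothing available accounts for this rise.

This single pair replaces a chain of three carbons carrying a double bond with a saturated group of four carbons, so it cannot show whether the loss of the double bond or the larger group matters; n-propyl, isopropyl and n-butyl on the same nitrogen would separate the two. It also leaves open whether the exchange gives a similar step when the sulfonyl sulfur carries 2,3-dihydro-1H-inden-5-yl.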